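Urea Replacement on the Shared Core: Compound 4 Expected

A few compounds are considered here, and "the series" means these few. Any claim that something is new, unique, unknown or untested is made for them only; others in the source may bear on it.

Measured compounds:
- compound 1, `COc1ccc(OCC(=O)N2CCN(c3nc(N)nc4sccc34)CC2)cc1`: 72 nM
- compound 2, `Nc1nc(N2CCN(C(=O)COc3ccc(F)cc3)CC2)c2ccsc2n1`: 66 nM
- compound 3, `Nc1nc(N2CCN(C(=O)COc3ccc(Br)cc3)CC2)c2ccsc2n1`: 320 nM

In a functional assay on cells (Lymphocyte) (on this read-out higher numbers stand for weaker inhibition and lower numbers for stronger inhibition), compound 3 stands at the highest number of the three. Its nearest neighbour is compound 1, with the step of a 4.4-fold higher number from compound 1 to compound 3 (0.65 log units; beyond the scatter); the step of a 4.8-fold higher number from compound 2 to compound 3 (0.69 log units; beyond the scatter) is of similar size, while a 1.1-fold lower number from compound 1 to compound 2 (0.04 log units; within the scatter) lies within the scatter.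

Compound 4, `Nc1nc(N2CCN(C(=O)Nc3ccc(Cl)cc3)CC2)c2ccsc2n1`, differs from compound 3 in one place: (4-chlorophenyl)amino in place of (4-bromophenoxy)methyl on a carbonyl carbon. Going by the values given here, no measured step covers this change, since every measured compound carries the phenoxymethyl group on the carbonyl carbon and none carries an arylamino group there. The measured steps speak only to the aromatic substituent: bromo gave the higher numbers, while fluoro and methoxy sat close together. Chloro has not been tested. With the linker change unexplored, the size and direction of the step cannot be read from the data, and a wide range is the honest expectation.

Compound 4 is therefore estimated at 150 nM, with a range from 40 nM to 600 nM, which corresponds to an expected step of a 2.1-fold lower number from compound 3 to compound 4 (0.33 log units; beyond the scatter) in this assay.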

Compound 4, half-maximal inhibitory concentration: 6700 nM
Compound 4: middle estimate off by 45-fold (1.65 log units), on the low side; measured number outside the range, above it.
By their numbers in this assay, from the lowest: compounds 2 and 1 (each within the scatter of the next); then compound 3; then compound 4.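

In this assay, the change on the carbonyl carbon outweighs the steps seen so far on the aromatic ring: the exchange of (4-bromophenoxy)methyl for (4-chlorophenyl)amino gives a 21-fold higher number from compound 3 to compound 4 (1.32 log units; beyond the scatter), and the exchange of (4-fluorophenoxy)methyl for the same group gives a 100-fold higher number from compound 2 to compound 4 (2.01 log units; beyond the scatter). Both steps are large, whereas the earlier aromatic substitutions gave steps no bigger than modest, so this position on the carbonyl carbon, whose other neighbour is the amide-type nitrogen in a ring, is the more sensitive of the two places varied here, at least for this change. Nothing available explains the loss, although the count shows that the entering group brings a hydrogen-bond donor and the leaving group a hydrogen-bond acceptor.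

The compounds shown leave open how the step divides between the amino linkage and the chloro substituent, as the change replaces both together and (4-chlorophenoxy)methyl does not appear among them. Also open, going by these compounds, is how the reading would respond to a methylated (4-chlorophenyl)amino group, a 4-chlorobenzyl group or a longer chain on the same carbonyl carbon.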